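The source may hold more compounds than are shown below. What is called first, only, known or untested is meant among the compounds shown, and "the series" means these compounds.

Compound 1 `COc1cc(OC)c(OC)cc1/C=C/COC(=O)/C=C/c1ccc(Br)cc1` gives 100% in a functional assay on the whole organism (strain Kunming) with Mus musculus as the target, with a stated time of 0.5 h, at a dose of 100 mg/kg by the intraperitoneal route; a higher number here means a weaker effect of the compound at the dose given, a lower number a stronger effect.
Compound 2 `COc1ccc(/C=C/C(=O)OC/C=C/c2cc(OC)c(OC)cc2OC)cc1` gives 100% in this assay.

Among the compounds with values here, compound 2 stands level with compound 1, the only measured neighbour: the step of no change at the digits printed from compound 1 to compound 2 (within the scatter) shows that swapping bromo for methoxy on an aromatic carbon left the read-out unmoved. Compound 3 `COc1cc(OC)c(OC)cc1/C=C/COC(=O)/C=C/c1ccc(Cl)cc1` differs from compound 2 by chloro in place of methoxy on an aromatic carbon. Within the data shown here, the one measured step bears on this directly, since compound 1 already carries a halogen at that aromatic carbon and matched compound 2. No change beyond the scatter is therefore expected in this assay. Compound 3 is estimated at 100%, expected between 88% and 100%, a step of no change at the digits printed from compound 2 to compound 3 (within the scatter).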

Compound 3, a percentage reported as activity, at one dose (the size of the read-out at that dose, not a potency): 100%
Compound 3: the middle estimate sits on the measured number at the digits printed; measured number inside the range.
By their numbers in this assay, from the lowest: compounds 1, 2 and 3 (each within the scatter of the next).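

In this assay the swap of methoxy for chloro at this aromatic carbon gives no change at the digits printed from compound 2 to compound 3 (within the scatter), and the swap of bromo for chloro gives no change at the digits printed from compound 1 to compound 3 (within the scatter). The second step adds a direct comparison of two halogens, so chloro, bromo and methoxy now stand level at this carbon in these compounds. Nothing measured here offers an explanation for this level result.

From the compounds shown here alone, whether an amine or a carboxylic acid at this carbon would shift the read-out remains open. So does the effect of a longer chain there, or of a change elsewhere on the shared core.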